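The source may report more compounds than this note shows. Statements on the series, on what has been measured and on what is new or still open speak of the compounds shown alone.

Measured compounds in the series:

- compound 2 `COc1c(N2CCn3cc(C(=O)O)nc3C2)c(F)cc2c(=O)c(C(=O)O)cn(C3CC3)c12` — 141000 nM
- compound 3 `COc1c(N2CCC3(CC2)OCCO3)c(F)c([N+](=O)[O-])c2c(=O)c(C(=O)O)cn(C3CC3)c12` — 135000 nM
- compound 1 `COc1c(N2CCN(C(c3ccccc3)c3ccc(Cl)cc3)CC2)c(F)cc2c(=O)c(C(=O)O)cn(C3CC3)c12` — "not determined" (no result reported)

In an ADME assay on Vero cells (Chlorocebus sabaeus) for cytotoxicity, read by MTT assay, with a stated time of 72 h (on this read-out higher numbers stand for weaker inhibition and lower numbers for stronger inhibition), compound 2 gives 141000 nM, and compound 3 gives 135000 nM. These two numbers lie within the scatter of each other, so compound 2 cannot be placed apart from compound 3 on this read-out. Compound 1 has no result in this assay.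

Compound 4 `COc1c(N2CCn3cc(C(=O)O)nc3C2)c(F)c([N+](=O)[O-])c2c(=O)c(C(=O)O)cn(C3CC3)c12` is still to be measured. Relative to compound 2 it carries nitro in place of hydrogen on an aromatic carbon. For the measured compounds named here, no pair of measured compounds differs in a single place, so the size of this change cannot be read off directly. Compound 3, which also bears a nitro group, gives 135000 nM in this assay, close to compound 2. On this basis the step from compound 2 to compound 4 is expected to stay within the scatter, a 1.0-fold lower number from compound 2 to compound 4 (0.02 log units; within the scatter), with no clear direction. Compound 4 is expected to come in at 135000 nM, with a range from 65000 nM to 280000 nM.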

Compound 4, half-maximal inhibitory concentration: 128000 nM
Compound 4: the middle estimate sits 1.1-fold (0.02 log units) above what was measured; low and high end bracket the measured number.
By their numbers in this assay, from the lowest: compounds 4, 3 and 2 (each within the scatter of the next).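

In this assay, the series now has its first pair differing in one place: with nitro in place of hydrogen on an aromatic carbon, ortho to a fluoro group and para to a methoxy group, the step is a 1.1-fold lower number from compound 2 to compound 4 (0.04 log units; within the scatter). This position therefore takes a group of 3 heavy atoms on this core with no change beyond the scatter on this read-out, a result that a comparison across different side groups could not give. No measurement bears on why this step is so small.

From the compounds shown here alone, whether an amino group or a methyl group at this position would also stay within the scatter remains open. A single pair also leaves open whether the nitro step is the same with other large groups on the core.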